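The compounds below may be only part of what the source reports. "The series", "measured", "known", "first", "only" and "open" are said of these compounds alone.

Measured compounds in a functional assay on HepG2 cells (Homo sapiens) for antiproliferative activity, read by MTT assay, with a stated time of 48 h; on this read-out lower numbers stand for stronger inhibition and higher numbers for weaker inhibition:

Compound 1 `COc1ccc(-n2nncc2CN2C(=O)C3(C(C#N)=C(N)Oc4c3c3nc5ccccc5nc3c3ccccc43)c3ccccc32)cc1` gives > 50000 nM, which is a limit of this assay and not a number.
Compound 2 `N#CC1=C(N)Oc2c(c3nc4ccccc4nc3c3ccccc23)C12C(=O)N(Cc1cnnn1-c1ccc(F)c(Cl)c1)c1ccccc12` gives > 50000 nM, again a limit of this assay.
Compound 3 `N#CC1=C(N)Oc2c(N)cc3nc4ccccc4nc3c2C12C(=O)N(Cc1cnnn1-c1ccc(F)cc1)c1ccccc12` gives > 50000 nM, likewise a limit of this assay.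

Compound 3 therefore stands at the limit of this assay, where every value of the series so far sits, as summarised in the limit of > 50000 nM in this assay, at which 3 of the 3 values shown sit; nothing separates it from the other two on the numbers shown.

The unmeasured compound 4 `N#CC1=C(N)Oc2c(N)cc3nc4ccccc4nc3c2C12C(=O)N(Cc1cnnn1-c1c(F)cccc1F)c1ccccc12` differs from compound 3 in one place: 2,6-difluorophenyl in place of 4-fluorophenyl on an aromatic nitrogen.

Among the compounds with values here, the only measured step that also changes the group on the aromatic nitrogen is a step that the two limits leave unreadable from compound 1 to compound 2, and the two limits leave its size unreadable. Within the data shown here, no step is read as a number, so no measured step bears on the change from compound 3 to compound 4 in a way that fixes a direction or a size. With the limit of > 50000 nM in this assay, at which 3 of the 3 values shown sit, covering all three values, the expectation is that the change will not move compound 4 away from the limit of this assay, and the expected step is a step that the limit leaves unreadable from compound 3 to compound 4, no step beyond the scatter. For compound 4 the estimate in this assay is 60000 nM, with the range 20000 nM to 200000 nM, most likely reported as a limit again.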

Compound 4, half-maximal inhibitory concentration: > 50000 nM
Compound 4 was reported as a limit; the forecaster's own chance of this, stated with the estimate: 85%; the middle value lies beyond the limit too.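

Compound 4 gives > 50000 nM in this assay, which is a limit and not a number. Compound 3 also sits at a limit, so no step can be read between compound 3 and compound 4. The compounds shown leave open which structural change, if any, would give a readable value in this assay, as the series so far sits at one value: the limit of > 50000 nM in this assay, at which 4 of the 4 values shown sit.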